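The source may hold more compounds than are shown below. What is called first, only, known or untested is meant among the compounds shown, and "the series" means these compounds.

Of the compounds shown here, two of one series have been measured in an assay on isolated protein for inhibition of serine/threonine-protein kinase TNNI3K (Homo sapiens); on this read-out lower numbers stand for stronger inhibition and higher numbers for weaker inhibition. Compound 1, `CNc1nccc(Oc2ccc(NC(=O)Nc3cccc(C(F)(F)F)c3)cc2)n1`, gives 50 nM in this assay. Compound 2, `C[C@H](O)CNc1cc(Oc2ccc(NC(=O)Nc3cccc(C(F)(F)F)c3)cc2)ncn1`, carries a (2-hydroxypropyl)amino group on its core, and in this assay compound 2 gives 32 nM. Of the two numbers recorded so far, compound 2 shows the lower one, but the gap to compound 1 lies within the usual scatter of repeated measurements, so the two compounds cannot be told apart on these data.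

Compound 3, `CC(=O)Nc1cc(Oc2ccc(NC(=O)Nc3cccc(C(F)(F)F)c3)cc2)ncn1`, has not yet been measured. It differs from compound 2 in one place: acetyl in place of 2-hydroxypropyl on a nitrogen on an aromatic ring, which turns the (2-hydroxypropyl)amino group into an acetamido group. For the measured compounds named here, no pair of measured compounds shows a change of this kind, so there is no measured step to lean on. Going by the values given here, since the only two values available, those of compound 1 and compound 2, sit close together, the expectation is a small step toward a weaker number, of a size that may not clear the scatter, a 2.5-fold higher number from compound 2 to compound 3 (0.40 log units; beyond the scatter). For compound 3 the value in this assay is estimated at 80 nM, with a range from 25 nM to 260 nM.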

Compound 3, half-maximal inhibitory concentration: 20 nM
The estimate for compound 3 lay 4.0-fold (0.60 log units) above the measured number; measured number below the stated range.
By their numbers in this assay, from the lowest: compounds 3, 2 and 1 (each within the scatter of the next, the first and the last beyond it).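

In this assay, acetyl in place of 2-hydroxypropyl on a nitrogen on an aromatic ring gives a 1.6-fold lower number from compound 2 to compound 3 (0.20 log units; within the scatter), so compound 2 and compound 3 cannot be told apart. At this position, then, the hydroxyl and the defined stereocentre of the 2-hydroxypropyl group are not required for a number in this range, since the acetamido group serves as well as the (2-hydroxypropyl)amino group. The other new step, a 2.5-fold lower number from compound 1 to compound 3 (0.40 log units; beyond the scatter), is the only one of the two to pass the scatter, but it exchanges 2-(methylamino)pyrimidin-4-yl for 6-acetamidopyrimidin-4-yl on an oxygen on an aromatic ring as a whole, so it cannot be credited to the acetyl group alone, and nothing available explains either step.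

Still open, from the compounds shown here alone, is whether a longer acyl chain such as propionyl, a methanesulfonyl group or a bare amine on the same nitrogen would keep the number in this range. Also open, going by these compounds, is whether an acetyl group on the nitrogen of the methylamino group of compound 1 would shift its number at all.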